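A few compounds are considered here, and "the series" means these few. Any claim that something is new, unique, unknown or untested is made for them only; others in the source may bear on it.

For the measured compounds named here, compound 1 `C=CCc1cc(C(C)=O)c(O)cc1OCCCCCCCCC#N` is one of two compounds measured in an assay on isolated protein for binding affinity to leukotriene B4 receptor 1 (Homo sapiens), tested at 1 uM; a higher number here means more inhibition at the concentration tested (going by the name of the read-out), a lower number less inhibition. In this assay compound 1 gives 50%, the lower of the two values, while compound 2 `CCc1cc(C(C)=O)c(O)cc1OCCCCCCC(C)(C)c1nnn[nH]1` gives 67%, a gap beyond the usual scatter. Compound 3 `C=CCc1cc(C(C)=O)c(O)cc1OCCCCCC(C)(C)O` has not yet been measured. It differs from compound 1 by 1-hydroxy-1-methylethyl in place of 3-cyanopropyl on a saturated chain carbon, five bonds along the chain from an oxygen on an aromatic ring. Going by the values given here, no measured pair shows this change, so its effect is unknown. Compound 3 is expected to give about 45%, with a plausible range from 20% to 70%. The expected step of a number 5 percentage points lower from compound 1 to compound 3 (within the scatter) is thus small and within the scatter.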

Compound 3, a percentage reported as inhibition, at one concentration (the size of the read-out at that concentration, not a potency): 60%
Compound 3: the middle estimate sits 15 percentage points below what was measured; the range from low to high includes it.
By their numbers in this assay, from the lowest: compounds 1, 3 and 2 (each within the scatter of the next, the first and the last beyond it).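

In this assay, 1-hydroxy-1-methylethyl in place of 3-cyanopropyl on a saturated chain carbon, five bonds along the chain from an oxygen on an aromatic ring, gives a number 10 percentage points higher from compound 1 to compound 3 (within the scatter). The nitrile is therefore not needed at this chain end to keep a reading in this range, and the exchange adds a hydrogen-bond donor without a difference that stands beyond the scatter. Nothing available explains this result. From the compounds shown here alone, whether a carboxylic acid, an amine or a longer chain at this position would move the reading beyond the scatter of compound 1 stays open.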